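The source may hold more compounds than are shown below. What is called first, only, known or untested is meant among the compounds shown, and "the series" means these compounds.

Values in a functional assay on HUVEC cells (Homo sapiens) for inhibition, with a stated time of 4 days; on this read-out higher numbers stand for weaker inhibition and lower numbers for stronger inhibition
- compound 1 `COc1ccc(C(N)=O)cc1/C=C/c1ccc(Cl)cc1` gives 87 nM
- compound 2 `COc1ccc(C(N)=O)cc1/C=C/c1ccc(F)cc1` gives 2100 nM
- compound 3 `COc1ccc(C(N)=O)cc1/C=C/c1ccc(Cl)c(Cl)c1` gives 560 nM

Compound 1 has the lowest number of the three, and so the strongest inhibition measured so far. Both measured steps away from it go upward. Fluoro in place of chloro on an aromatic carbon gives a 24-fold higher number from compound 1 to compound 2 (1.38 log units; beyond the scatter), a large step. Chloro in place of hydrogen on an aromatic carbon gives a 6.4-fold higher number from compound 1 to compound 3 (0.81 log units; beyond the scatter), a modest one.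

Compound 4 `CCNC(=O)c1ccc(OC)c(/C=C/c2ccc(Cl)cc2)c1` differs from compound 1 elsewhere, with ethyl in place of hydrogen on an amide-type nitrogen. Neither measured step touches that nitrogen, so both bear on this change only indirectly, showing how far single changes have moved the number in this small set. With compound 1 at 87 nM and both of its steps upward, a modest rise is expected in this assay, although the direction remains uncertain. The expected step is a 4.0-fold higher number from compound 1 to compound 4 (0.60 log units; beyond the scatter). For compound 4 the estimated value is 350 nM, with an expected range from 70 nM to 2000 nM.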

Compound 4, half-maximal inhibitory concentration: 160 nM
For compound 4 the middle estimate is 2.2-fold (0.34 log units) above the measured one; measured number inside the range.
By their numbers in this assay, from the lowest: compounds 1 and 4 (each within the scatter of the next); then compound 3; then compound 2.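

In this assay, among these compounds, ethyl in place of hydrogen on an amide-type nitrogen gives a 1.8-fold higher number from compound 1 to compound 4 (0.26 log units; within the scatter), the first measured change at this position. Unlike the two changes on aromatic carbons, whose steps lie beyond the scatter, this one stays within it, so in this single pair the amide hydrogen can give way to ethyl with no change that the assay can distinguish. No measured evidence is available to explain this result.

On these data alone, it remains open whether a longer chain, a cyclopropyl ring, or a chain carrying an amine or a carboxylic acid on the same nitrogen would also stay within the scatter of compound 1. As far as these compounds go, it is equally open whether ethyl would have the same effect alongside the fluoro of compound 2 or the added chloro of compound 3.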